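The source may hold more compounds than are shown below. What is called first, only, known or untested is meant among the compounds shown, and "the series" means these compounds.

Two nucleoside analogues have been tested in an ADME assay on CCRF-CEM cells (Homo sapiens) for cytotoxicity, read by cell counting, with a stated time of 3 days; on this read-out lower numbers stand for stronger inhibition and higher numbers for weaker inhibition. Compound 1, with the structure `O=c1[nH]c(=O)n([C@H]2C[C@H](O)[C@@H](CO)O2)cc1-c1cn(-c2ccccc2)nn1`, gives 75000 nM in this assay. Compound 2, with the structure `O=c1[nH]c(=O)n([C@H]2C[C@H](O)[C@@H](CO)O2)cc1-c1cnnn1-c1c(F)cccc1F`, gives 12000 nM in this assay. Of the two numbers, compound 2 holds the lower one; the number of compound 1 is higher by a margin that goes beyond the ordinary scatter of this assay, so compound 2 is the stronger inhibitor of cell growth among the pair.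

Compound 3, with the structure `O=c1[nH]c(=O)n([C@H]2C[C@H](O)[C@@H](CO)O2)cc1-c1cnnn1-c1ccc(Br)cc1`, has not yet been tested. It keeps the shared core of compound 2 and differs in a single place: 4-bromophenyl in place of 2,6-difluorophenyl on an aromatic nitrogen. Among the compounds with values here, no measured pair shows the effect of this exchange, so the expected size of the step rests on judgement alone. A modest move toward a higher number is expected, a step of a 2.1-fold higher number from compound 2 to compound 3 (0.32 log units; beyond the scatter) in this assay, near the edge of the scatter rather than clearly beyond it. On that basis compound 3 is estimated at 25000 nM in this assay, within a range from 6000 nM to 100000 nM.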

Compound 3, half-maximal inhibitory concentration: 47000 nM
Compound 3: middle estimate off by 1.9-fold (0.27 log units), on the low side, within the range that was stated.
By their numbers in this assay, from the lowest: compound 2; then compounds 3 and 1 (each within the scatter of the next).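

On an aromatic nitrogen of the five-membered aromatic ring, 4-bromophenyl in place of 2,6-difluorophenyl gives a 3.9-fold higher number from compound 2 to compound 3 (0.59 log units; beyond the scatter) in this assay, a modest change that lies beyond the scatter. This shows that the read-out responds to the group at this position, with the core and the rest of the molecule held the same. Compound 1 and compound 2 are not linked by a one-place step, so this is the only direct view of a single exchange so far, but no measurement at hand explains its direction.

From the compounds shown here alone, the exchange alters both the atoms on the phenyl ring and where they sit, so the share of the bromine, of the two fluorines and of their placement remains open. A plain phenyl group on this same nitrogen, or a phenyl ring bearing an amine or a carboxylic acid, would be needed to separate these contributions and to show how widely the read-out can move at this position.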